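Thioether pyrimidines on melanoma cells: chlorophenyl shift

A few compounds are considered here, and "the series" means these few. Any claim that something is new, unique, unknown or untested is made for them only; others in the source may bear on it.

The measured compounds:
compound 1 `C#CCSc1nc(Nc2ccccc2Cl)c(C#N)c(-c2ccccc2)n1` — 12400 nM
compound 2 `C#CCSc1nc(Nc2ccc(Cl)cc2)c(C#N)c(-c2ccccc2)n1` — 19800 nM
compound 3 `N#Cc1c(Nc2ccccc2Cl)nc(SCc2cn(Cc3ccccc3Cl)nn2)nc1-c1ccccc1` — 8350 nM

In a functional assay on B16-F10 cells (Mus musculus) for inhibition, read by MTT assay, with a stated time of 72 h (a lower number here means a stronger inhibitor, a higher number a weaker inhibitor), compound 1 gives 12400 nM, and compound 2 gives 19800 nM. The change between them is 4-chlorophenyl in place of 2-chlorophenyl on a nitrogen on an aromatic ring, and it produced a 1.6-fold higher number from compound 1 to compound 2 (0.20 log units; within the scatter). Compound 3 gives 8350 nM in this assay; the difference between the core of compound 3 and the core of compound 1 is not broken down here, so their values are only set side by side.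

Compound 4 `N#Cc1c(Nc2ccc(Cl)cc2)nc(SCc2cn(Cc3ccccc3Cl)nn2)nc1-c1ccccc1` carries the same change made on the core of compound 3: 4-chlorophenyl in place of 2-chlorophenyl on a nitrogen on an aromatic ring. The place is the same in both pairs, so the step is expected to be of similar size, resting on a 1.6-fold higher number from compound 1 to compound 2 (0.20 log units; within the scatter). Compound 4 is therefore expected to show a 1.6-fold higher number from compound 3 to compound 4 (0.19 log units; within the scatter), giving an estimate of 13000 nM, between 6000 nM and 30000 nM.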

Compound 4, half-maximal inhibitory concentration: 1590 nM
Compound 4: the middle estimate sits 8.2-fold (0.91 log units) above what was measured; measured number outside the range, below it.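

In this assay the change from 2-chlorophenyl to 4-chlorophenyl gave a 5.3-fold lower number from compound 3 to compound 4 (0.72 log units; beyond the scatter). The step seen on one core therefore did not carry over unchanged to the other: the same change on two cores in this assay, a 1.6-fold higher number (0.20 log units; within the scatter) from compound 1 to compound 2 and a 5.3-fold lower number (0.72 log units; beyond the scatter) from compound 3 to compound 4, 8.4-fold (0.92 log units) apart, beyond the scatter of two such steps

Among the compounds shown here, this shows that, in this series, the result of the change cannot simply be transferred between these two cores, but with only two pairs it does not show which part of the cores accounts for the gap or how the change would behave on any further core. Still open, as far as these compounds go, is how a fluorine or a methoxy group in place of the chlorine would behave on each core. From the compounds shown here alone, it is also open whether a plain phenyl on the nitrogen would show a similar gap between the cores.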